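Adding a Second Methoxy to a Chalcone-Pyrazole Growth Inhibitor

The source may report more compounds than this note shows. Statements on the series, on what has been measured and on what is new or still open speak of the compounds shown alone.

Measured compounds:
compound 1, `COc1ccc(-c2cc(/C=C/C(=O)c3ccc(N)cc3)[nH]n2)cc1`, 3360 nM
compound 2, `COc1ccc(C(=O)/C=C/c2cc(-c3cc(OC)c(OC)c(OC)c3)n[nH]2)cc1`, 3400 nM

In a functional assay on HCC 2998 cells (Homo sapiens) for inhibition, read by sulforhodamine B assay, with a stated time of 48 h (a lower number here means a stronger inhibitor of growth, a higher number a weaker inhibitor of growth), compound 1 gives 3360 nM. Of the two numbers recorded it is the lower one, but compound 2 stands within the scatter of it, with 3400 nM in this assay, so the two cannot be placed in order. For the measured compounds named here, no step between measured compounds differing in a single place is available.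

Compound 3, `COc1ccc(-c2cc(/C=C/C(=O)c3ccc(N)cc3)[nH]n2)cc1OC`, is not yet measured. It differs from compound 1 by methoxy in place of hydrogen on an aromatic carbon. Going by the values given here, no measured pair shows what this change does here, so the expectation rests on compound 1 alone and on the view that a small addition of this kind more often than not leaves a number of this size roughly where it is. For this reason the step of a 1.1-fold lower number from compound 1 to compound 3 (0.05 log units; within the scatter) is expected to stay within the scatter, with no firm direction. The value for compound 3 in this assay is estimated at 3000 nM, with a range from 1200 nM to 8000 nM.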

Compound 3, concentration for total growth inhibition: 3830 nM
Estimate against measurement, compound 3: 1.3-fold (0.11 log units) below; low and high end bracket the measured number.
By their numbers in this assay, from the lowest: compounds 1, 2 and 3 (each within the scatter of the next).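

In this assay, for the compounds shown here, the added methoxy, on an aromatic carbon ortho to a methoxy group and meta to a large group, gives a 1.1-fold higher number from compound 1 to compound 3 (0.06 log units; within the scatter), and this is the first comparison here of compounds that differ in one place. It shows that, on this ring and in this one cell line, the position accepts methoxy in place of hydrogen with no change that can be told from the scatter. Nothing on hand offers an explanation for this result.

The compounds shown leave open whether a different group at this place, such as an amine, a hydroxyl or a fluorine, would also leave the number where it is. They also leave open whether a longer chain, such as ethoxy, would be accepted in the same way.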